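Phenyl for cyclopropylethynyl on a saturated ring carbon

The source may report more compounds than this note shows. Statements on the series, on what has been measured and on what is new or still open speak of the compounds shown alone.

Compound 1 `O=c1nc2c(cn1Cc1ccccc1)ncn2Cc1ccccc1`: 16%
Compound 2 `O=C1Nc2c(ncn2Cc2ccccc2)C(C#CC2CC2)N1Cc1ccccc1`: 90%

In a functional assay on K562 cells (Homo sapiens) for cytotoxicity, read by thymidine incorporation, with a stated time of 5 h, tested at 10 ug/mL (a higher number here means more inhibition at the concentration tested (going by the name of the read-out), a lower number less inhibition), compound 1 gives 16%, and compound 2 gives 90%. Compound 2 stands highest of the two numbers; the nearest, compound 1, lies a long way lower, well beyond the scatter. The two differ in several places, so their gap cannot be tied to any single change.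

Compound 3 `O=C1Nc2c(ncn2Cc2ccccc2)C(c2ccccc2)N1Cc1ccccc1` differs from compound 2 in one place: phenyl in place of 2-cyclopropylethynyl on a saturated ring carbon. Within the data shown here, no measured pair shows what this exchange does in this assay, so any expectation rests on compound 2 alone. A drop of moderate size is expected, a number 20 percentage points lower from compound 2 to compound 3 (beyond the scatter), though no change beyond the scatter would not surprise. In this assay compound 3 is expected to give about 70%, with a range from 35% to 95%.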

Compound 3, a percentage reported as inhibition, at one concentration (the size of the read-out at that concentration, not a potency): 69%
The estimate for compound 3 lay 1 percentage points above the measured number; low and high end bracket the measured number.
By their numbers in this assay, from the lowest: compound 1; then compound 3; then compound 2.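

Placing phenyl in place of 2-cyclopropylethynyl on the saturated ring carbon gives, in this assay, a number 21 percentage points lower from compound 2 to compound 3 (beyond the scatter). The position therefore responds to this exchange, yet the triple bond and the three-membered ring are not needed for substantial inhibition, since compound 3 still gives 69%. This is one pair at one concentration, so it shows a change in the size of the read-out and not a change in potency, and nothing at hand explains the step.

As far as these compounds go, it remains open how this ring carbon would respond to a group of another kind, such as an amine, a carboxylic acid or a simple longer alkyl chain. Nor do the compounds shown tell whether a phenyl ring bearing substituents would move the number in either direction.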